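A few compounds are considered here, and "the series" means these few. Any claim that something is new, unique, unknown or untested is made for them only; others in the source may bear on it.

Compound 1 `COc1ccc(-c2cc(=O)c3c(OC)cc(OC)cc3n2Cc2ccccc2)cc1` has been run in an ADME assay on BJ cells (Homo sapiens) for antiproliferative activity, with a stated time of 72 h; a lower number here means that less compound is needed, a higher number that more compound is needed for the effect. In this assay compound 1 returns only a limit, > 34400 nM, not a number. Compound 2 `COC(=O)c1cc(=O)c2cc(N)ccc2[nH]1` likewise returns only a limit in this assay, > 67200 nM. For the measured compounds named here, no measured pair differing in a single place exists here, so no measured step size is available. Compound 3 `COc1ccc(-c2cc(=O)c3c(OC)cc(OC)cc3n2S(=O)(=O)c2cccc(Br)c2)cc1` is not yet measured; relative to compound 1 it carries (3-bromophenyl)sulfonyl in place of benzyl on an aromatic nitrogen. Given compound 1 at its limit (the limit of > 34400 nM in this assay, at which 1 of the 2 values shown sits), no step beyond the usual scatter is expected in either direction. The estimated step is a step that the limit leaves unreadable from compound 1 to compound 3. For compound 3 the expected value in this assay is 40000 nM, within 15000 nM to 110000 nM, most likely again reported only as a limit.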

Compound 3, half-maximal effective concentration: > 58600 nM
Compound 3: only a limit was reported (the forecaster's own chance of this, stated with the estimate: 75%); middle value at least 1.4-fold (0.16 log units) away from the limit.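

For the compounds shown here, compound 1 and compound 3 both return only limits in this assay, so no step between them can be read. The compounds shown leave open whether replacing benzyl with (3-bromophenyl)sulfonyl changes the half-maximal effective concentration, and in which direction.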